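Amide aryl swap in a weak antiproliferative series

The compounds below may be only part of what the source reports. "The series", "measured", "known", "first", "only" and "open" are said of these compounds alone.

Compound 1 `COC(=O)c1scc(-c2ccc(NC(=O)c3ccccn3)cc2)c1OC` carries a pyridin-2-yl group on the amide carbonyl. Within the data shown here, in a functional assay on K562 cells (Homo sapiens) for antiproliferative activity, read by MTT assay, with a stated time of 24 h (a higher number here means a weaker inhibitor, a lower number a stronger inhibitor), compound 1 gives 24200 nM, the higher of the two numbers measured so far. Among the measured compounds shown here, the only comparison compound is compound 2 `COC(=O)c1scc(-c2ccc(NC(=O)c3ccc(C(F)(F)F)cc3Br)cc2)c1OC`, which in this assay gives 9250 nM; the gap between compound 1 and compound 2 lies beyond the usual scatter, so compound 2 is the stronger inhibitor of the pair, although the two differ in more than one place and no single step can be drawn between them.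

Compound 3 `COC(=O)c1scc(-c2ccc(NC(=O)c3cccc(I)c3)cc2)c1OC` is the next to be measured. 3-iodophenyl in place of pyridin-2-yl on a carbonyl carbon The shared core and the amide linkage are untouched. Compound 2, at 9250 nM, shows that a carbon-only aromatic ring bearing halogen on that carbonyl can sit below the pyridin-2-yl amide of compound 1, though its ring carries a different set of groups. The step of a 2.0-fold lower number from compound 1 to compound 3 (0.30 log units; within the scatter) is expected to be a modest lowering, somewhat beyond the scatter. Compound 3 is accordingly estimated at 12000 nM, with a range from 5000 nM to 30000 nM.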

Compound 3, half-maximal inhibitory concentration: 14700 nM
Compound 3: middle estimate off by 1.2-fold (0.09 log units), on the low side, and the stated range covers the measured number.
By their numbers in this assay, from the lowest: compounds 2, 3 and 1 (each within the scatter of the next, the first and the last beyond it).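

In this assay, putting 3-iodophenyl in place of pyridin-2-yl on a carbonyl carbon gives a 1.6-fold lower number from compound 1 to compound 3 (0.22 log units; within the scatter), the first single-place step available in the series, and it does not separate the two compounds. At this position, then, a six-membered aromatic ring of carbon only bearing iodine and a pyridin-2-yl ring with its single hydrogen-bond acceptor read alike, so this swap does not by itself take the series out of its weak range. No independent data are at hand to account for this outcome.

Because the step removes the ring nitrogen and adds iodine at once, the two contributions remain unseparated, and a plain phenyl ring on the same carbonyl would be needed to tell them apart. Also open, as far as these compounds go, is whether a chlorine atom, a methoxy group, an amine or a carboxylic acid in place of the iodine would move the number beyond the scatter, or whether this position stays as flat as this single step suggests.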